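The compounds below may be only part of what the source reports. "The series", "measured", "known", "first", "only" and "open" are said of these compounds alone.

Measured in a functional assay on L1210 cells (Mus musculus) for antiproliferative activity; a higher number here means a weaker inhibitor, a lower number a stronger inhibitor:
- compound 1 `COc1ccc(-c2cc(N)c(C(=O)c3cc(OC)c(OC)c(OC)c3)s2)cc1OC`: 40 nM
- compound 2 `COc1cc(C(=O)c2sc(-c3ccccc3)cc2N)cc(OC)c1OC`: 11 nM

Compound 2, at 11 nM, holds the lower of the two numbers, and its gap to compound 1 lies beyond the scatter. The next compound is compound 3 `COc1cc(C(=O)c2sc(-c3ccc(F)cc3)cc2N)cc(OC)c1OC`, which differs from compound 2 as follows: fluoro in place of hydrogen on an aromatic carbon. In words, fluoro replaces hydrogen on an aromatic carbon, turning phenyl into 4-fluorophenyl.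

For the measured compounds named here, only one measured step bears on this change: a 3.6-fold lower number from compound 1 to compound 2 (0.56 log units; beyond the scatter). That modest step involved the same aromatic group, so this position does respond to substitution. Going by the values given here, it involved no fluoro, however, and the data hold no example of adding a single fluoro here, so they give no direction for this change. With only a single heavy atom entering, no change beyond the scatter is expected in this assay, although the uncertainty remains wide. The expected step is a 1.1-fold higher number from compound 2 to compound 3 (0.04 log units; within the scatter). Compound 3 is estimated at 12 nM, with an expected range of 4 nM to 35 nM.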

Compound 3, half-maximal inhibitory concentration: 20 nM
The estimate for compound 3 lay 1.7-fold (0.22 log units) below the measured number; measured number inside the range.
By their numbers in this assay, from the lowest: compounds 2, 3 and 1 (each within the scatter of the next, the first and the last beyond it).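

In this assay the series now holds its first direct case of a single fluoro entering at this place, and turning phenyl into 4-fluorophenyl gives a step that stays within the scatter (a 1.8-fold higher number from compound 2 to compound 3 (0.26 log units; within the scatter)). The comparison with the 3,4-dimethoxyphenyl group also stays within the scatter (a 2.0-fold lower number from compound 1 to compound 3 (0.30 log units; within the scatter)), whereas phenyl and 3,4-dimethoxyphenyl are separated by a step beyond it (a 3.6-fold lower number from compound 1 to compound 2 (0.56 log units; beyond the scatter)), so 4-fluorophenyl cannot be told apart from either of the other two, although those two can be told apart from each other. Nothing available accounts for the size of these steps.
Going by these compounds, whether a chloro, a bromo, a single methoxy, an amine or a carboxylic acid in place of the fluoro would move the number beyond the scatter from compound 2 remains open. Also open, on these data alone, is whether a fluoro added to the 3,4-dimethoxyphenyl group of compound 1 would give a step as small as the one seen on phenyl.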